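Removing the Bromo Substituent from the Sulfonamide Aryl Ring

A few compounds are considered here, and "the series" means these few. Any claim that something is new, unique, unknown or untested is made for them only; others in the source may bear on it.

Compound 1 `COc1ccc(S(=O)(=O)NCCN2CCC(CCC(=O)c3cc(Cl)c(N)cc3OC)CC2)cc1Br` and compound 2 `COc1cc(N)c(Cl)cc1C(=O)CCC1CCN(CCNS(=O)(=O)c2ccc(N)c(Br)c2)CC1` belong to the same series and share a common core. In an assay on HEK293 cells for displacement of a labelled ligand from 5-hydroxytryptamine receptor 6 (Homo sapiens), with a stated time of 60 min, tested at 0.01 uM, in the presence of a further agent that is not named here (on this read-out higher numbers stand for a stronger effect at the one concentration tested and lower numbers for a weaker effect), compound 1 was reported as "not active" (no number reported), with no number attached. In this assay, for the measured compounds named here, compound 2 gives 39%, which is the only number in this set, the other entry being reported without a single figure. Compound 3 `COc1cc(N)c(Cl)cc1C(=O)CCC1CCN(CCNS(=O)(=O)c2ccc(N)cc2)CC1` has not yet been measured. The change from compound 2 to compound 3 is hydrogen in place of bromo on an aromatic carbon. Going by the values given here, no pair of measured compounds differing in one place is available, so the size of such a step cannot be read from these data. The expected step in this assay is a number 12 percentage points lower from compound 2 to compound 3 (beyond the scatter), a modest loss that may not clear the usual scatter. For compound 3 the estimate in this assay is 27%, within a range from 8% to 48%.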

Compound 3, a percentage reported as inhibition, at one concentration (the size of the read-out at that concentration, not a potency): 7%
Compound 3: middle estimate off by 20 percentage points, on the high side; the measured number lies below the stated range.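

Taking bromo off the aromatic carbon ortho to the amino group gives the first step that can be read at this position: in this assay the change gives a number 32 percentage points lower from compound 2 to compound 3 (beyond the scatter). Within this pair, then, the read-out depends strongly on a single bromine atom on the 4-amino-3-bromophenyl group, a change of one heavy atom with no hydrogen-bond donor or acceptor involved, which the earlier compounds, with no pair differing in one place, could not show. Nothing measured here bears on the reason for this step.

Going by these compounds, what chloro, fluoro or a methyl group on this same carbon would give remains open, so the step cannot yet be tied to bromo alone rather than to any group there. On these data alone, the read-out also comes from a single concentration and is not a potency, so the size of this change in potency stays open as well.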